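Swapping 3,4-dimethoxyphenyl for 4-bromophenyl on a shared core

The source may report more compounds than this note shows. Statements on the series, on what has been measured and on what is new or still open speak of the compounds shown alone.

Compound 1 `C/C(=N\NC(=O)/C(C#N)=C/c1ccccc1)c1c(O)c2ccc(O)cc2oc1=O`: 15800 nM
Compound 2 `COc1ccc(/C=C(\C#N)C(=O)N/N=C(\C)c2c(O)c3ccc(O)cc3oc2=O)cc1OC`: 13500 nM
Compound 3 `COc1cc(/C=C(\C#N)C(=O)N/N=C(\C)c2c(O)c3ccc(O)cc3oc2=O)cc(OC)c1OC`: 18500 nM

All three compounds were tested in a functional assay on HeLa cells (Homo sapiens) for cytotoxicity, read by MTT assay, with a stated time of 24 h; on this read-out higher numbers stand for weaker inhibition and lower numbers for stronger inhibition. Compound 2 gives 13500 nM, and its steps to compound 1 and compound 3 both stay within the scatter, so it stands level with them. The unmeasured compound 4 `C/C(=N\NC(=O)/C(C#N)=C/c1ccc(Br)cc1)c1c(O)c2ccc(O)cc2oc1=O` differs from compound 2 in one group: 4-bromophenyl in place of 3,4-dimethoxyphenyl on a double-bonded chain carbon bound to a double-bonded chain carbon.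

Among the compounds with values here, two measured steps bear on this change. Replacing phenyl with 3,4-dimethoxyphenyl gave a 1.2-fold lower number from compound 1 to compound 2 (0.07 log units; within the scatter), and adding a methoxy gave a 1.4-fold higher number from compound 2 to compound 3 (0.14 log units; within the scatter). Within the data shown here, no measured compound carries bromine, so this evidence is indirect. No step beyond the scatter is therefore expected in this assay, in either direction.

The expected change is a 1.1-fold higher number from compound 2 to compound 4 (0.05 log units; within the scatter).

For compound 4 the estimate is 15000 nM, with an expected range of 7500 nM to 30000 nM.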

Compound 4, half-maximal inhibitory concentration: 10600 nM
Compound 4: the middle estimate sits 1.4-fold (0.15 log units) above what was measured, and the stated range covers the measured number.
By their numbers in this assay, from the lowest: compounds 4, 2, 1 and 3 (each within the scatter of the next).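

In this assay, 4-bromophenyl in place of 3,4-dimethoxyphenyl gives a 1.3-fold lower number from compound 2 to compound 4 (0.11 log units; within the scatter), and bromo in place of hydrogen on an aromatic carbon gives a 1.5-fold lower number from compound 1 to compound 4 (0.17 log units; within the scatter). A bromine-bearing ring therefore stands level with the plain phenyl and methoxy-bearing rings, so this place has now taken a halogen without a step beyond the scatter. Nothing measured here explains these small steps. Still open, going by these compounds, is whether an amine or a carboxylic acid at this place would move the number beyond the scatter.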